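This account rests on a few compounds, and the source may have more. Where it says the series, first, only, none or still open, it means among the compounds named here.

Measured compounds:
compound 1, `Cc1cc(-c2noc(C(F)(F)F)n2)cc(C)c1OCCC(C)CCN1CCN(c2ccnc(N)c2)C1=O`, > 100000 nM
compound 2, `Cc1nc(-c2ccc(OCCC(C)CCN3CCN(c4ccnc(N)c4)C3=O)cc2)no1`, 66100 nM
compound 3, `CCONC(=O)c1ccc(OCCC(C)CCN2CCN(c3ccnc(N)c3)C2=O)cc1`, > 100000 nM

In an ADME assay on RD cells (Homo sapiens) for cytotoxicity, read by MTT assay, with a stated time of 24 h (on this read-out higher numbers stand for lower toxicity in this test and lower numbers for higher toxicity in this test), compound 1 gives only a limit of the assay, > 100000 nM. Compound 3 likewise gives only a limit in this assay, > 100000 nM. Compound 2 gives a number in this assay, 66100 nM, so all three compounds with the shared core sit in the same weakly toxic region, and compound 1 stands at the limit of > 100000 nM in this assay, at which 2 of the 3 values shown sit.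

The compound not yet measured, compound 4 `CCCc1nc(-c2cc(C)c(OCCC(C)CCN3CCN(c4ccnc(N)c4)C3=O)c(C)c2)no1`, differs from compound 1 by propyl in place of trifluoromethyl on an aromatic carbon. For the measured compounds named here, no measured step touches this position. The single step shown, an at least 1.5-fold higher number from compound 2 to compound 3 (0.17 log units; that floor lies within the scatter), changes a different part of the molecule and is only a floor lying within the scatter; it shows that exchanging the substituent on the aromatic ring of compound 2 hardly moves the read-out. Going by the values given here, with compound 1 at > 100000 nM and nothing among the measured compounds pointing to a rise in toxicity, compound 4 is expected to stay near compound 1. Compound 4 is therefore estimated at about 90000 nM in this assay, within 35000 nM to 100000 nM, most probably again reported only as a limit. That estimate means an at least 1.1-fold lower number from compound 1 to compound 4 (0.04 log units; that floor lies within the scatter), a step expected to remain within the scatter.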

Compound 4, half-maximal cytotoxic concentration: 14100 nM
Compound 4: the middle estimate sits 6.4-fold (0.81 log units) above what was measured; measured number outside the range, below it.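

In this assay, for the compounds shown here, the earlier compounds offered no step beyond the scatter, and none touched the substituent on the five-membered aromatic ring, so nothing yet showed that this position could move the read-out. Replacing trifluoromethyl with propyl on this aromatic carbon, turning 5-(trifluoromethyl)-1,2,4-oxadiazol-3-yl into 5-propyl-1,2,4-oxadiazol-3-yl, now gives an at least 7.0-fold lower number from compound 1 to compound 4 (0.85 log units; beyond the scatter), so the position is not indifferent and this exchange brings a higher toxicity in this test. The step is only a floor, and compound 4 now stands apart from the compounds that reach the limit: the limit of > 100000 nM in this assay, at which 2 of the 4 values shown sit.

As far as these compounds go, it remains open whether the shift comes from the loss of trifluoromethyl or the arrival of propyl, and a methyl group, a longer chain such as butyl or an amine on the same carbon would help to separate the two. From the compounds shown here alone, the true size of the step also remains open, and no measured property here accounts for it, so whether the same exchange would act alike on another member of the series is equally unsettled.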